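Swapping 4-methoxyphenyl for methyl in compound 3

The compounds below may be only part of what the source reports. "The series", "measured", "known", "first", "only" and "open" are said of these compounds alone.

In a functional assay on Ramos cells (Homo sapiens) for antiproliferative activity, read by CCK-8 assay, with a stated time of 24 h (a lower number here means a stronger inhibitor, a higher number a weaker inhibitor), compound 1 (`C=CC(=O)Nc1cc(Nc2ncnc(Nc3ccc(C(=O)N4CCCCC4)cc3)n2)ccc1C`) gives 48500 nM and compound 2 (`C=CC(=O)Nc1cccc(Nc2ncnc(Nc3ccc(C(=O)N4CCCCC4)cc3)n2)c1`) gives 6140 nM. That step is modest: a 7.9-fold lower number from compound 1 to compound 2 (0.90 log units; beyond the scatter).

Compound 3 (`C=CC(=O)Nc1cccc(Nc2ncnc(Nc3ccc(Oc4ccc(OC)cc4)cc3)n2)c1`) gives only a limit, > 100000 nM, which is the limit of > 100000 nM in this assay, at which 1 of the 3 values shown sits.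

Compound 4 (`C=CC(=O)Nc1cccc(Nc2ncnc(Nc3ccc(OC)cc3)n2)c1`) differs from it as follows: methyl in place of 4-methoxyphenyl on an oxygen on an aromatic ring. This is methyl in place of 4-methoxyphenyl on an oxygen on an aromatic ring.

The closest measured change is the large step that introduced 4-methoxyphenoxy: an at least 16-fold higher number from compound 2 to compound 3 (1.21 log units; beyond the scatter). Compound 4 keeps only the methoxy, so part of that step is expected to reverse, towards a lower number.

The expected step is an at least 4.0-fold lower number from compound 3 to compound 4 (0.60 log units; beyond the scatter).

For compound 4 the estimated value is 25000 nM, within an expected range of 7000 nM to 90000 nM.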

Compound 4, half-maximal inhibitory concentration: 90000 nM
Compound 4: middle estimate off by 3.6-fold (0.56 log units), on the low side; the range from low to high includes it.
By their numbers in this assay, from the lowest: compound 2; then compounds 1 and 4 (each within the scatter of the next). At a limit, above all of these: compound 3.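

Cutting 4-methoxyphenoxy back to methoxy gives an at least 1.1-fold lower number from compound 3 to compound 4 (0.04 log units; that floor lies within the scatter) in this assay, so no gain from removing the 4-methoxyphenyl can be claimed. Compound 3 gives only a limit, not a number: the limit of > 100000 nM in this assay, at which 1 of the 4 values shown sits.

The comparison with the amide reads a 15-fold higher number from compound 2 to compound 4 (1.17 log units; beyond the scatter) and shows that the loss relative to (piperidin-1-yl)carbonyl does not require the 4-methoxyphenyl, since it persists with methoxy alone.

On these data alone, it remains open whether an amine or a carboxylic acid at this place would match compound 2. As far as these compounds go, it also remains open whether a simple dimethylamide would retain the level of compound 2 without the piperidine ring.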